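The source may hold more compounds than are shown below. What is called first, only, known or untested is meant among the compounds shown, and "the series" means these compounds.

Among the measured compounds shown here, compound 1 `C#CCOc1ccc(/C=C/C(=O)c2cccc(OC)c2)cc1OC` gives 5590 nM in a functional assay on CCRF-CEM cells (Homo sapiens) for cytotoxicity, with a stated time of 72 h (on this read-out higher numbers stand for weaker inhibition and lower numbers for stronger inhibition), one of only two plain numbers reported here. For the measured compounds named here, compound 2 `C#CCOc1ccc(/C=C/C(=O)c2ccc(OC)c(OC)c2)cc1OC` gives 8650 nM, and the sole one-place step, a 1.5-fold higher number from compound 1 to compound 2 (0.19 log units; within the scatter), is a change too small to read as a difference. Compound 3 `C#CCOc1ccc(C(CC(=O)c2cccc(C)c2)CC(=O)c2cccc(C)c2)cc1OC` reaches only a limit, > 50000 nM, which is the limit of > 50000 nM in this assay, at which 1 of the 3 values shown sits. Compound 4 `C#CCOc1ccc(/C=C/C(=O)c2ccc(C)cc2)cc1OC` differs from compound 1 by 4-methylphenyl in place of 3-methoxyphenyl on a carbonyl carbon. Going by the values given here, no measured step touches that ring; the one step available, a methoxy addition, stays within the scatter, so no movement beyond the scatter is expected in either direction. Compound 4 is therefore expected to give about 6000 nM in this assay, within 2500 nM to 15000 nM. That estimate corresponds to an expected 1.1-fold higher number from compound 1 to compound 4 (0.03 log units; within the scatter).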

Compound 4, half-maximal inhibitory concentration: > 50000 nM
Compound 4: no number, only a limit; the forecaster's own chance of this, stated with the estimate: 5%; middle value at least 8.3-fold (0.92 log units) from the limit.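

Placing 4-methylphenyl instead of 3-methoxyphenyl on the carbonyl carbon gives an at least 8.9-fold higher number from compound 1 to compound 4 (0.95 log units; beyond the scatter), so this ring can't be changed freely in this assay, whereas the earlier methoxy addition stayed within the scatter. Compound 4 gives only a limit, not a number, so the full size of this loss remains unknown: the limit of > 50000 nM in this assay, at which 2 of the 4 values shown sit.

As far as these compounds go, both the group and its place on the ring differ, so it stays open which of the two carries the loss. From the compounds shown here alone, how a ring carrying an amine or a carboxylic acid would read in this assay also stays open.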